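Ester change on two cores: one step measured, one expected

The compounds below may be only part of what the source reports. "The series", "measured", "known", "first", "only" and "open" are said of these compounds alone.

Compound 1 `CC(C)CCOC(=O)/C(C#N)=C/c1ccoc1`: 82.2%
Compound 2 `N#C/C(=C\c1ccoc1)C(=O)OC1CCCCC1`: 91.2%
Compound 3 `CC(C)CCOC(=O)/C(C#N)=C/c1cc2ccccc2[nH]1`: 46.6%

In a functional assay on the whole organism (strain CD1) for inhibition, with Mus musculus as the target, with stated times of 15 min and 20 min, at a dose of 10 mg/kg by the subcutaneous route (on this read-out higher numbers stand for more inhibition at the one dose given (going by the name of the read-out) and lower numbers for less inhibition), compound 1 gives 82.2% and compound 2 gives 91.2%. The two differ by a single change, (cyclohexyl in place of isopentyl on an oxygen next to a carbonyl group), and the step is a number 9 percentage points higher from compound 1 to compound 2 (within the scatter), so the two values cannot be told apart. Compound 3 gives 46.6%, the lowest of the three, beyond the scatter from both others; the difference between its core and the core of compound 1 is not broken down here.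

Compound 4 `N#C/C(=C\c1cc2ccccc2[nH]1)C(=O)OC1CCCCC1` has not yet been measured in this assay. It differs from compound 3 by cyclohexyl in place of isopentyl on an oxygen next to a carbonyl group, the same change as from compound 1 to compound 2, at the same place. Since that change gave only a number 9 percentage points higher from compound 1 to compound 2 (within the scatter), compound 4 is expected to stay near compound 3, with an estimated step of a number 7.4 percentage points higher from compound 3 to compound 4 (within the scatter). The estimate for compound 4 in this assay is 54%, expected to fall between 36% and 72%.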

Compound 4, a percentage reported as inhibition, in the whole organism at one dose (the size of the read-out at that dose, not a potency): 83.6%
Compound 4: middle estimate off by 29.6 percentage points, on the low side, outside the stated range (above it).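

In this assay, putting cyclohexyl in place of isopentyl on an oxygen next to a carbonyl group gives a number 37 percentage points higher from compound 3 to compound 4 (beyond the scatter) on the core of compound 3, a step that stands apart from the one on the core of compound 1. The two steps differ in size: the same change on two cores in this assay, a number 9 percentage points higher (within the scatter) from compound 1 to compound 2 and a number 37 percentage points higher (beyond the scatter) from compound 3 to compound 4, 28 percentage points apart, beyond the scatter of two such steps. This shows that, for these two pairs, the size of the step does not carry over from one core to the other, so the step on one core is a poor guide to the step on the other; it does not show what causes the difference, or how the same change would run on any further core.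

The compounds shown leave open whether the gap between the two cores also holds for other esters, such as a benzyl ester or one with a longer chain. They also leave open what an amide or a carboxylic acid would give in place of the ester on either core.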